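Aryl swap on the amine of a shared core

This account rests on a few compounds, and the source may have more. Where it says the series, first, only, none or still open, it means among the compounds named here.

Of the compounds shown here, three built on the same core have been measured in a functional assay on MGC-803 cells (Homo sapiens) for inhibition, read by sulforhodamine B assay; a lower number here means a stronger inhibitor, a higher number a weaker inhibitor. Compound 1 `O=C1C=C(Nc2ccc(I)cc2)C(=O)c2c1nc1n2[C@H]2OC[C@@H](O)[C@H]2OC1` gives 1400 nM, compound 2 `Cc1ccc(NC2=CC(=O)c3nc4n(c3C2=O)[C@H]2OC[C@@H](O)[C@H]2OC4)cc1C` gives 860 nM, and compound 3 `O=C1C(Nc2cccc(Cl)c2)=CC(=O)c2c1nc1n2[C@H]2OC[C@@H](O)[C@H]2OC1` gives 1530 nM. On these three numbers compound 3 carries the highest value, but its gaps to compound 1 and to compound 2 both sit within the scatter, so no ordering among the three can be claimed. Going by the values given here, the one step with a single change, a 1.6-fold lower number from compound 1 to compound 2 (0.21 log units; within the scatter), also stays within the scatter.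

Compound 4 `COc1ccc(NC2=CC(=O)c3c(nc4n3[C@H]3OC[C@@H](O)[C@H]3OC4)C2=O)cc1` differs from compound 3 by 4-methoxyphenyl in place of 3-chlorophenyl on an amine nitrogen. The step from compound 1 to compound 2 is the only one that bears on this, as it too exchanges one aryl group on the amine nitrogen, and it moved the number little. Compound 4 is therefore expected to stay close to compound 3, with a 1.3-fold lower number from compound 3 to compound 4 (0.11 log units; within the scatter) estimated to lie within the scatter in this assay. The estimate for compound 4 is 1200 nM, with a range from 500 nM to 3000 nM.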

Compound 4, half-maximal inhibitory concentration: 2150 nM
For compound 4 the middle estimate is 1.8-fold (0.25 log units) below the measured one, and the stated range covers the measured number.
By their numbers in this assay, from the lowest: compounds 2, 1, 3 and 4 (each within the scatter of the next, the first and the last beyond it).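

In this assay, 4-methoxyphenyl in place of 3-chlorophenyl on the amine nitrogen gives a 1.4-fold higher number from compound 3 to compound 4 (0.15 log units; within the scatter), so a second aryl exchange at this nitrogen also stays within the scatter, now with an oxygen-bearing group entering. Across the four aryl groups, only the two ends of the series are printed as beyond the scatter of each other, with compound 2 at 860 nM and compound 4 at 2150 nM, while every neighbouring pair stays within it. No measurement shown gives a reason for these numbers.

From the compounds shown here alone, all four compounds carry a substituted phenyl on this nitrogen, so it remains open how an unsubstituted phenyl, a pyridine ring or a cyclohexyl group would read in this assay. Also open, going by these compounds, is whether 3-methoxyphenyl would read apart from 4-methoxyphenyl on the same nitrogen.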